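The source may hold more compounds than are shown below. What is called first, only, known or untested is meant among the compounds shown, and "the series" means these compounds.

Measured compounds:
compound 1 `CS(=O)(=O)c1cccc(-c2ccc(-n3cc(-c4ccccc4)nn3)cc2)c1` — in a functional assay on MCF7 cells (Homo sapiens) for inhibition, read by resazurin assay, with a stated time of 72 h (on this read-out higher numbers stand for weaker inhibition and lower numbers for stronger inhibition), compound 1 gives < 50000 nM, which is a limit of the assay and not a number.
compound 2 `Fc1ccc(Cl)cc1-c1ccc(-n2cc(-c3ccccc3)nn2)cc1` — in this assay compound 2 gives < 50000 nM, again a limit of the assay rather than a number.

Compound 2 therefore stands at the limit, and nothing more can be said of its position: both values shown sit at the same limit (the limit of < 50000 nM in this assay, at which 2 of the 2 values shown sit). Among the compounds with values here, no step between measured compounds is recorded, so the two limits show only that neither compound fell outside the range covered by the assay; no order between compound 1 and compound 2 follows from them.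

Compound 3 `c1ccc(-c2ccc(-n3cc(-c4ccccc4)nn3)cc2)cc1` remains to be measured in this assay. It differs from compound 2 by phenyl in place of 5-chloro-2-fluorophenyl on an aromatic carbon, para to a large group. Within the data shown here, with only limits in hand and no measured step to lean on, no direction can be read from the series; the expected step in this assay is none beyond the scatter, with a fair chance that the assay again reports only a limit. Compound 3 is accordingly estimated at 20000 nM, within 5000 nM to 50000 nM, which means an expected step that the limit leaves unreadable from compound 2 to compound 3.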

Compound 3, half-maximal inhibitory concentration: < 50000 nM
Compound 3: no number, only a limit (the forecaster's own chance of this, stated with the estimate: 60%); the middle value is on the limit's open side.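

In this assay compound 3 gives < 50000 nM, a limit of the assay and not a number. The steps to compound 3 from compound 1 and from compound 2 therefore cannot be read: the limit of < 50000 nM in this assay, at which 3 of the 3 values shown sit. The compounds shown leave open how strongly each one inhibits in this assay, and whether the groups separating them make any difference.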